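This account rests on a few compounds, and the source may have more. Where it says the series, first, only, none or still open, it means among the compounds named here.

Working notes on the series. Compound 1 `Cc1cc(C)nc(SCc2cc(=O)c3cc(Cl)ccc3o2)n1` gives in a functional assay on HEp-2 cells (Homo sapiens) for cytotoxicity, read by MTT assay, with a stated time of 72 h (a lower number here means a stronger inhibitor, a higher number a weaker inhibitor), only a limit, > 25000 nM, which is the limit of > 25000 nM in this assay, at which 1 of the 3 values shown sits. Compound 2 `Cc1nnc(Sc2coc3ccccc3c2=O)s1` also gives only a limit in this assay, > 50000 nM, which is the limit of > 50000 nM in this assay, at which 1 of the 3 values shown sits. Going by the values given here, compound 3 `Cc1nnc(SCc2coc3ccc(Cl)cc3c2=O)o1` is the one member with a measured number, 6400 nM in this assay. With the other two values being limits, no order among the three can be set. Compound 4 `Cc1nnc(SCc2coc3ccc(Cl)cc3c2=O)s1` is not yet measured; it differs from compound 3 by 5-methyl-1,3,4-thiadiazol-2-yl in place of 5-methyl-1,3,4-oxadiazol-2-yl on a sulfur. Among the compounds with values here, no measured step of this kind exists, so the expected step in this assay is a 1.2-fold lower number from compound 3 to compound 4 (0.07 log units; within the scatter), none beyond the scatter. The estimate for compound 4 in this assay is 5500 nM, expected between 1800 nM and 20000 nM.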

Compound 4, half-maximal inhibitory concentration: 4200 nM
For compound 4 the middle estimate is 1.3-fold (0.12 log units) above the measured one; low and high end bracket the measured number.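

In this assay, going by these compounds alone, the first measured step on a sulfur whose other neighbour is a saturated chain carbon reads a 1.5-fold lower number from compound 3 to compound 4 (0.18 log units; within the scatter) for 5-methyl-1,3,4-thiadiazol-2-yl in place of 5-methyl-1,3,4-oxadiazol-2-yl. At this place the two five-membered rings therefore cannot be told apart in this read-out. No measured property shown bears on this result.

Open, from the compounds shown here alone, is what an amine or a carboxylic acid on this sulfur would give in this assay. Also open, going by these compounds, is how a longer chain in place of the saturated chain carbon would read.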